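Bromo to nitro on the benzyl ring: working notes

The source may report more compounds than this note shows. Statements on the series, on what has been measured and on what is new or still open speak of the compounds shown alone.

Measured in a functional assay on MDA-MB-231 cells (Homo sapiens) for inhibition, read by sulforhodamine B assay; on this read-out higher numbers stand for weaker inhibition of growth and lower numbers for stronger inhibition of growth:
- compound 1 `Cc1ccc(CN2CCC=C(CCC(=O)NO)C2=O)cc1`: 1430 nM
- compound 2 `O=C(CCC1=CCCN(Cc2ccc(Br)cc2)C1=O)NO`: 1630 nM

Set against compound 1, the only other measured compound, compound 2 gives 1630 nM, and the two cannot be told apart. The next change, to compound 3 `O=C(CCC1=CCCN(Cc2ccc([N+](=O)[O-])cc2)C1=O)NO`, is nitro in place of bromo on an aromatic carbon, para to a large group (nitro in place of bromo on an aromatic carbon). Going by the values given here, one measured step bears on it, made at the same place: a 1.1-fold higher number from compound 1 to compound 2 (0.06 log units; within the scatter), with bromo in place of methyl. Among the compounds with values here, that is a single small step, and no nitro compound has been measured, so the data give no direction. No step beyond the scatter is expected in this assay. For compound 3 the expected value is 1500 nM, with an estimated range of 700 nM to 3200 nM. This estimate amounts to an expected 1.1-fold lower number from compound 2 to compound 3 (0.04 log units; within the scatter).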

Compound 3, concentration for 50% growth inhibition: 470 nM
Estimate against measurement, compound 3: 3.2-fold (0.50 log units) above; measured number outside the range, below it.
By their numbers in this assay, from the lowest: compound 3; then compounds 1 and 2 (each within the scatter of the next).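

Nitro in place of bromo on this aromatic carbon moves the number beyond the scatter in this assay (a 3.5-fold lower number from compound 2 to compound 3 (0.54 log units; beyond the scatter)), and nitro in place of methyl does the same (a 3.0-fold lower number from compound 1 to compound 3 (0.48 log units; beyond the scatter)). The position therefore responds to the group it carries, which the step from methyl to bromo alone did not reveal, and among these three groups only nitro stands apart, with compound 1 and compound 2 within the scatter of each other. Nothing available explains why nitro separates from bromo and methyl.

Open, from the compounds shown here alone, is whether this lower number is particular to nitro or would also appear with a nitrile, a trifluoromethyl, a carboxylic acid or an amine on the same carbon. Also open, going by these compounds, is whether nitro on a different carbon of the ring would give a similar step.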